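An Epimer of a Diester That Sits at the Limit

The source may report more compounds than this note shows. Statements on the series, on what has been measured and on what is new or still open speak of the compounds shown alone.

Compound 2 `COc1ccc(C(=O)O[C@H]2CC(C)=C[C@@H](OC(C)=O)[C@@]3(C)[C@@H](OC(C)=O)C[C@@](O)(C(C)C)[C@H]23)cc1` is one of three compounds tested in a functional assay on HeLa cells (Homo sapiens) for cytotoxicity, read by MTT assay, with a stated time of 72 h; on this read-out lower numbers stand for stronger inhibition and higher numbers for weaker inhibition. Compound 2 gives only a limit there, > 100000 nM. Compound 3 `COc1ccc(C(=O)O[C@H]2CC(C)=C[C@@H](O)[C@@]3(C)[C@@H](OC(C)=O)C[C@@](O)(C(C)C)[C@H]23)cc1` likewise gives only a limit, > 100000 nM. Compound 1 `CC1=CC[C@]2(C)[C@@H]([C@@H](OC(=O)c3ccc(O)cc3)C1)[C@](O)(C(C)C)C[C@@H]2O` gives 56500 nM. For the measured compounds named here, the single measured step, a step that the two limits leave unreadable from compound 2 to compound 3, cannot be read because of the limit of > 100000 nM in this assay, at which 2 of the 3 values shown sit. Compound 4 `COc1ccc(C(=O)O[C@H]2CC(C)=C[C@H](OC(C)=O)[C@@]3(C)[C@@H](OC(C)=O)C[C@@](O)(C(C)C)[C@H]23)cc1` differs from compound 2 as follows: the two compounds have the same atoms and bonds and differ only in configuration as drawn: 1 of 6 stereo elements differ; a stereocentre at a saturated ring carbon is drawn R in compound 2 and S in compound 4. Going by the values given here, none of the measured steps concerns a change of configuration alone, so these results give no direction for the step to compound 4. The step of a number no higher from compound 2 to compound 4 (the limit leaves the size open) is therefore expected to be none beyond the scatter. Compound 4 is expected to remain at the limit, with an estimated value of 100000 nM, between 40000 nM and 300000 nM.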

Compound 4, half-maximal inhibitory concentration: 14500 nM
For compound 4 the middle estimate is 6.9-fold (0.84 log units) above the measured one; measured number below the stated range.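

In this assay, the inversion of this one saturated ring carbon gives an at least 6.8-fold lower number from compound 2 to compound 4 (0.83 log units; beyond the scatter), the first sign among these compounds that configuration alone moves the read-out. The size of the step remains open because compound 2 sits at a limit: the limit of > 100000 nM in this assay, at which 2 of the 4 values shown sit. The shift can be tied to this stereocentre alone because nothing else changes: the fact that compounds 2 and 4 differ only in the configuration as drawn

On these data alone, the step from compound 2 to compound 3 cannot be read, so the effect of removing an acetyl remains unknown. As far as these compounds go, whether the lower number would persist with an amine at this carbon also stays open.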